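A few compounds are considered here, and "the series" means these few. Any claim that something is new, unique, unknown or untested is made for them only; others in the source may bear on it.

Measured compounds:
compound 1 `COc1ccc(C2CC(c3ccccc3)=NN2c2nc(-c3ccccc3)c(C#N)c(=O)n2C)cc1` gives 12800 nM in a functional assay on MDA-MB-231 cells (Homo sapiens) for antiproliferative activity, with a stated time of 72 h; on this read-out higher numbers stand for weaker inhibition and lower numbers for stronger inhibition
compound 2 `Cn1c(N2N=C(c3ccccc3)CC2c2ccc(Cl)cc2)nc(-c2ccc(Cl)cc2)c(C#N)c1=O` gives 25100 nM in this assay

Compound 2 and compound 1 lie within the usual scatter of each other in this assay, so the two numbers show no real separation; compound 2 is simply one of two weak inhibitors. Compound 3 `COc1ccc(C2CC(c3ccccc3)=NN2c2nc(-c3ccc(Cl)cc3)c(C#N)c(=O)n2C)cc1` has not yet been measured. It differs from compound 2 in one place: methoxy in place of chloro on an aromatic carbon. Going by the values given here, since no step between measured compounds isolates this change, there is nothing in the present numbers to suggest a move beyond the scatter, and compound 3 is expected to remain in the weak range of its two neighbours. For compound 3 the estimated value in this assay is 16000 nM, with a range from 5000 nM to 50000 nM. The expected step from compound 2 is therefore a 1.6-fold lower number from compound 2 to compound 3 (0.20 log units; within the scatter), a change within the scatter.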

Compound 3, half-maximal inhibitory concentration: 19500 nM
The estimate for compound 3 lay 1.2-fold (0.09 log units) below the measured number; the measured number falls inside the stated range.
By their numbers in this assay, from the lowest: compounds 1, 3 and 2 (each within the scatter of the next).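

In this assay, the exchange of 4-chlorophenyl for 4-methoxyphenyl gives a 1.3-fold lower number from compound 2 to compound 3 (0.11 log units; within the scatter) and so stays within the scatter. Going by these compounds alone, this is the first reading of this position through a single change, and it shows no separation between chloro and methoxy on this aromatic carbon. A second single change, chloro in place of hydrogen on an aromatic carbon, gives a 1.5-fold higher number from compound 1 to compound 3 (0.18 log units; within the scatter) and also shows no real separation, while no independent measurement is available to explain either result. Going by these compounds, what an amine or a carboxylic acid on the same aromatic carbon would do remains open. So does whether any exchange at this position can move the number beyond the scatter, and whether the two changes would behave the same way on a different background.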